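The compounds below may be only part of what the source reports. "The series", "measured", "known", "first", "only" and "open" are said of these compounds alone.

Compound 1 `COC(=O)c1ccc(NCc2cncn2Cc2ccc([N+](=O)[O-])cc2)cc1-c1ccccc1` was examined in a toxicity assay on NIH3T3 cells (Mus musculus) for cytotoxicity, read by resazurin assay; a higher number here means that more compound is needed for the effect, a lower number that less compound is needed. In this assay compound 1 gives > 10000 nM, and that value is a limit of the assay rather than a number. A close relative, compound 2 `O=[N+]([O-])c1ccc(Cn2cncc2CNc2cccc(-c3ccccc3)c2)cc1`, differs from compound 1 by hydrogen in place of methoxycarbonyl on an aromatic carbon; in this assay compound 2 gives 10000 nM. The step of a number no higher from compound 1 to compound 2 (the limit leaves the size open) cannot be sized, because compound 1 sits at the limit of > 10000 nM in this assay, at which 1 of the 2 values shown sits. So the one measured step leaves the picture open: both compounds stand at or near the top of what the assay can report.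

Compound 3 `COC(=O)c1ccc(NCc2cncn2Cc2cccc(Cl)c2)cc1-c1ccccc1` has not yet been measured. It differs from compound 1 by 3-chlorophenyl in place of 4-nitrophenyl on a saturated chain carbon bound to an aromatic nitrogen. Among the compounds with values here, no measured step touches this part of the molecule, so there is no direct guide to how the change will play out. Given that compound 1 stands at > 10000 nM, the step of a number no higher from compound 1 to compound 3 (the limit leaves the size open) is expected to be small, and compound 3 is estimated to show 10000 nM, within a range of 3000 nM to 30000 nM, most likely again reported only as a limit.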

Compound 3, half-maximal effective concentration: > 10000 nM
Compound 3: only a limit was reported; the forecaster's own chance of this, stated with the estimate: 65%; the middle value sits exactly at the limit.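

In this assay compound 3 gives > 10000 nM, which is a limit of the assay and not a number. Compound 1 also stands at a limit, so no step can be read between compound 1 and compound 3: the limit of > 10000 nM in this assay, at which 2 of the 3 values shown sit. The compounds shown leave open how much compound either one needs for the effect, and whether 3-chlorobenzyl in place of 4-nitrobenzyl changes that amount at all.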